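Pyrrolidine in Place of Imidazole on an Aryl Sulfonamide

The source may hold more compounds than are shown below. What is called first, only, known or untested is meant among the compounds shown, and "the series" means these compounds.

Compound 1 `O=S(=O)(Nc1cccc2c1CCCC2c1c[nH]cn1)c1ccc2ccccc2c1` gives 100 nM in an assay on isolated protein for binding affinity to Alpha-1D adrenergic receptor (Rattus norvegicus), read by radioligand binding; on this read-out higher numbers stand for weaker inhibition and lower numbers for stronger inhibition. Compound 2 `CCS(=O)(=O)Nc1cccc2c1CCCC2(O)c1c[nH]cn1` returns only a limit in this assay, < 10000 nM. Compound 3 `CCS(=O)(=O)Nc1cccc(-c2c[nH]cn2)c1` likewise returns only a limit in this assay, < 10000 nM. Compound 3 therefore stands at the limit rather than at a number, sharing that position with compound 2, as summed up by the limit of < 10000 nM in this assay, at which 2 of the 3 values shown sit. Compound 4 `CCS(=O)(=O)Nc1cccc(C2CCNC2)c1` carries pyrrolidin-3-yl in place of 1H-imidazol-4-yl on an aromatic carbon. No measured pair differs in this way, so the size of the step cannot be read from the data shown. Compound 4 is expected to remain weak, with an estimated step that the limit leaves unreadable from compound 3 to compound 4 that is not expected to exceed the scatter. Compound 4 is estimated at 8000 nM, within 2000 nM to 30000 nM.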

Compound 4, inhibition constant: 1000 nM
Compound 4: middle estimate off by 8.0-fold (0.90 log units), on the high side; the measured number lies below the stated range.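

Compound 3 stands only at a limit, so no step from it to compound 4 can be read: the limit of < 10000 nM in this assay, at which 2 of the 4 values shown sit.

The compounds shown leave open how large a change pyrrolidin-3-yl brings in place of 1H-imidazol-4-yl.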